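Aryl amine swap on the shared core: expectation for compound 3

A few compounds are considered here, and "the series" means these few. Any claim that something is new, unique, unknown or untested is made for them only; others in the source may bear on it.

Measured so far:
compound 1 `CCS(=O)(=O)Nc1cc(-c2ccc3ncnc(Nc4ccc(F)cc4F)c3c2)cnc1OC`: 4010 nM
compound 2 `CCS(=O)(=O)Nc1cc(-c2ccc3ncnc(Nc4ccc(C(=O)OC)c(OC)c4)c3c2)cnc1OC`: 1690 nM

In a functional assay on HCT-116 cells (Homo sapiens) for cytotoxicity, read by sulforhodamine B assay, with a stated time of 72 h (on this read-out higher numbers stand for weaker inhibition and lower numbers for stronger inhibition), compound 2 gives 1690 nM, the lowest of the two numbers. Compound 1 gives 4010 nM. Among the compounds with values here, the only step available, a 2.4-fold lower number from compound 1 to compound 2 (0.38 log units; beyond the scatter), concerns exactly the position changed here. Compound 3 `CCS(=O)(=O)Nc1cc(-c2ccc3ncnc(Nc4ccc(F)nc4)c3c2)cnc1OC` carries 6-fluoropyridin-3-yl in place of 3-methoxy-4-(methoxycarbonyl)phenyl on a nitrogen on an aromatic ring. The entering group resembles the 2,4-difluorophenyl of compound 1 more than the group it replaces, so most of the gain seen in that step is expected to be given back. Compound 3 is therefore expected to give about 3500 nM (range 1500 nM to 8000 nM), an expected step of a 2.1-fold higher number from compound 2 to compound 3 (0.32 log units; beyond the scatter).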

Compound 3, half-maximal inhibitory concentration: 7620 nM
For compound 3 the middle estimate is 2.2-fold (0.34 log units) below the measured one, within the range that was stated.
By their numbers in this assay, from the lowest: compound 2; then compounds 1 and 3 (each within the scatter of the next).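

At this place, on a nitrogen on an aromatic ring, this assay shows a 4.5-fold higher number from compound 2 to compound 3 (0.65 log units; beyond the scatter) when 6-fluoropyridin-3-yl replaces 3-methoxy-4-(methoxycarbonyl)phenyl. With 6-fluoropyridin-3-yl in place of 2,4-difluorophenyl, the result is a 1.9-fold higher number from compound 1 to compound 3 (0.28 log units; within the scatter) and these two fluorinated groups are not separated, leaving compound 2 alone apart from both. Nothing available accounts for this difference.

Still open, going by these compounds, is whether the methoxycarbonyl or the methoxy of compound 2 accounts for its lower number. A carboxylic acid or a primary amide at that point on the same ring would bear on this.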